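The compounds below may be only part of what the source reports. "The series", "measured", "known", "first", "only" and "open" are said of these compounds alone.

Compound 1, `O=C(O)c1cnc(-c2ccccc2Cl)[nH]c1=O`, in a functional assay on the whole organism (strain Sprague-Dawley) for inhibition, with Rattus norvegicus as the target, with a stated time of 10 min (on this read-out higher numbers stand for an effect only at larger amounts of compound and lower numbers for an effect already at smaller amounts), gives 5 mg/kg. Compound 3, `CCOC(=O)c1cnc(-c2ccccc2Cl)[nH]c1=O`, carries ethyl in place of hydrogen on an oxygen next to a carbonyl group, and in this assay compound 3 gives 5 mg/kg. The step of no change at the digits printed from compound 1 to compound 3 (within the scatter) shows that this exchange leaves the read-out where it was. Compound 2, `CCOc1ccc(S(=O)(=O)Cl)cc1-c1ncc(C(=O)O)c(=O)[nH]1`, belongs to the same series, but in this assay compound 2 has "not determined" (no result reported), so it adds no number. Compound 3 therefore stands level with compound 1 at the digits shown, with no other measured neighbour to set it against.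

Compound 4, `C=CCOc1ccccc1-c1ncc(C(=O)OCC)c(=O)[nH]1`, differs from compound 3 at the six-membered ring of carbon only: allyloxy in place of chloro on an aromatic carbon. Within the data shown here, no measured step concerns a change on that ring; the single measured step, from compound 1 to compound 3, concerns the ester oxygen and shows no movement. There is thus no measured basis for a step in either direction, and the expectation for compound 4 in this assay is a step of no change at the digits printed from compound 3 to compound 4 (within the scatter), that is, none beyond the scatter, though with wider uncertainty than the ester step would suggest. Compound 4 is accordingly estimated at 5 mg/kg, within a range from 1.5 mg/kg to 17 mg/kg.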

Compound 4, dose for 50% inhibition: 0.5 mg/kg
Compound 4: middle estimate off by 10-fold (1.00 log units), on the high side; the measured number lies below the stated range.
By their numbers in this assay, from the lowest: compound 4; then compounds 1 and 3 (each within the scatter of the next).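

With a 10-fold lower number from compound 3 to compound 4 (1.00 log units; beyond the scatter) in this assay, the exchange of chloro for allyloxy shows that this aromatic carbon, ortho to a large group, is a place where the read-out responds, with the effect now appearing at smaller amounts of compound. The earlier step concerned only the ester oxygen and moved nothing, so this is the first change among the compounds shown to shift the number beyond the scatter, and it comes with more heavy atoms, a double bond outside the aromatic rings and a hydrogen-bond acceptor that chloro does not bring. Nothing measured here accounts for the step or assigns it to any one of these features.

The compounds shown leave open whether the ether oxygen, the double bond or the length of the chain carries the step, a question that methoxy, propoxy or plain hydrogen at this place would help to separate. They also leave open whether allyloxy would act in the same way alongside the free carboxylic acid of compound 1 rather than the ethyl ester of compound 4.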